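Swapping a Bromine for a Nitro Group on Compound 1

The compounds below may be only part of what the source reports. "The series", "measured", "known", "first", "only" and "open" are said of these compounds alone.

Of the compounds shown here, two sharing the same core have been tested in a functional assay on A549 cells (Homo sapiens) for antiproliferative activity, read by XTT assay, with a stated time of 24 h; a lower number here means a stronger inhibitor, a higher number a weaker inhibitor. Compound 1, with the structure `Fc1ccc(C2CC(c3ccc(Cl)s3)=NN2c2nc(-c3ccc(Br)cc3)cs2)cc1`, gives 62.5 ug/mL in this assay, the lowest of the two numbers recorded. Compound 2, with the structure `Cc1ccc(C2=NN(c3nc(-c4ccc(C#N)cc4)cs3)C(c3ccc(F)cc3)C2)s1`, gives 322 ug/mL in this assay, a higher number than compound 1 by a margin that lies beyond the scatter of repeated measurements. These two compounds differ in more than one place, so no single structural change can be tied to that gap.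

Compound 3, with the structure `O=[N+]([O-])c1ccc(-c2csc(N3N=C(c4ccc(Cl)s4)CC3c3ccc(F)cc3)n2)cc1`, has not yet been measured. It differs from compound 1 in one place only: nitro in place of bromo on an aromatic carbon. Within the data shown here, no measured pair in this set shows what such a change does, so the direction of the step is open. A step of modest size, in either direction or none beyond the scatter, is what is expected here, and the estimate for the step from compound 1 to compound 3 is a 1.0-fold lower number from compound 1 to compound 3 (0.02 log units; within the scatter). Compound 3 is therefore expected to give about 60 ug/mL in this assay, with a plausible range from 20 ug/mL to 180 ug/mL.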

Compound 3, half-maximal inhibitory concentration: > 500 ug/mL
Compound 3 ended at the assay's limit; the forecaster's own chance of this, stated with the estimate: 10%; middle value at least 8.3-fold (0.92 log units) away from the limit.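

In this assay, among these compounds, the change from 4-bromophenyl to 4-nitrophenyl gives an at least 8.0-fold higher number from compound 1 to compound 3 (0.90 log units; beyond the scatter), the first step in this set that can be tied to a single place in the structure. For compound 3, the value > 500 ug/mL is a limit of the assay and not a number, so the step has a lower bound but no known full size: the limit of > 500 ug/mL in this assay, at which 1 of the 3 values shown sits. This shows that the position para to a large group is not indifferent to what it carries, since with the rest of the molecule unchanged, nitro in place of bromo moves the result beyond the scatter and towards weaker inhibition.

One replacement at one position cannot show whether this loss is peculiar to nitro or would follow from other replacements of bromo, and the data give no measured property that explains it. Going by these compounds, how an amine or a carboxylic acid at this same position would read stays open, as does whether the step would keep its direction on a compound that differs from compound 1 elsewhere in the structure.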